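A few compounds are considered here, and "the series" means these few. Any claim that something is new, unique, unknown or untested is made for them only; others in the source may bear on it.

Working notes on the chalcone series.

Among the compounds with values here, compound 1 has the structure `COc1ccc(/C=C/C(=O)c2ccc(OC)c([N+](=O)[O-])c2)cc1OC` and compound 2 the structure `COc1ccc(OC)c(C(=O)/C=C/c2ccc([N+](=O)[O-])cc2)c1`; the two differ in where the nitro and methoxy groups sit, and no single-point step between them is defined here. In a functional assay on B16 cells (Mus musculus) for cytotoxicity, read by MTT assay, with a stated time of 3 days (a lower number here means a stronger inhibitor, a higher number a weaker inhibitor), compound 1 returns only the limit > 100000 nM, not a number. In this assay compound 2 likewise returns only the limit > 100000 nM. Both measured values therefore sit at the limit of > 100000 nM in this assay, at which 2 of the 2 values shown sit, so compound 2 stands at the top of the range shown, with no measured number anywhere in the series to anchor a step size.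

Compound 3, structure `COc1ccc(OC)c(C(=O)/C=C/c2ccc(N)cc2)c1`, is the next entry to be measured in this assay. Its change from compound 2 is amino in place of nitro on an aromatic carbon. Within the data shown here, no measured step exists for this change, and since compound 2 is itself only a limit, any movement in this assay can be read only as an expectation. A gain in potency for compound 3 is possible but unsupported, so the expected step is placed near the scatter.

The estimate for compound 3 in this assay is 80000 nM, with a range of 15000 nM to 300000 nM. The expected step is an at least 1.2-fold lower number from compound 2 to compound 3 (0.09 log units; that floor lies within the scatter), with a substantial chance that compound 3 again returns only the limit.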

Compound 3, half-maximal inhibitory concentration: > 100000 nM
Compound 3: a limit, no number; the forecaster's own chance of this, stated with the estimate: 55%; middle value at least 1.2-fold (0.09 log units) from the limit.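

In this assay compound 3 returns > 100000 nM, a limit and not a number. No step can therefore be read between compound 2 and compound 3, and the series offers no number: the limit of > 100000 nM in this assay, at which 3 of the 3 values shown sit.

The compounds shown leave open how far, if at all, amino in place of nitro on an aromatic carbon moves the value in this assay.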